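Cytotoxicity notes: changing the benzylic group on the amine

The source may hold more compounds than are shown below. What is called first, only, known or untested is meant among the compounds shown, and "the series" means these compounds.

Compound 1 `CCCCOc1ccc(CN(Cc2ccc(C(C)(C)C)cc2)Cc2cc3cc(C)ccc3[nH]c2=O)cc1`, compound 2 `Cc1ccc2[nH]c(=O)c(CN(Cc3ccc(OC(F)(F)F)cc3)Cc3ccc(C(C)(C)C)cc3)cc2c1` and compound 3 `Cc1ccc2[nH]c(=O)c(CN(Cc3ccc(OC(F)F)cc3)Cc3ccc(C(C)(C)C)cc3)cc2c1` share one core and differ only in the group on an oxygen on an aromatic ring. In a toxicity assay on MDCK cells (Canis lupus familiaris) for cytotoxicity, read by crystal violet staining, with a stated time of 48 h (on this read-out lower numbers stand for higher toxicity in this test and higher numbers for lower toxicity in this test), compound 1 gives > 5000 nM, which is a limit of the assay and not a number. In this assay compound 2 gives > 5000 nM, again only a limit. Compound 3 stands at > 5000 nM in this assay, also a limit. Accordingly the steps a step that the two limits leave unreadable from compound 1 to compound 2, a step that the two limits leave unreadable from compound 1 to compound 3 and a step that the two limits leave unreadable from compound 2 to compound 3 cannot be sized; what remains is the limit of > 5000 nM in this assay, at which 3 of the 3 values shown sit.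

Compound 4 `COc1ccc(C(C)N(Cc2ccc(C(C)(C)C)cc2)Cc2cc3cc(C)ccc3[nH]c2=O)cc1` is the compound still to be measured. (1-(4-methoxyphenyl)ethyl in place of 4-(difluoromethoxy)benzyl on an amine nitrogen). Among the compounds with values here, none of the measured steps touches this position; the three steps concern the oxygen on an aromatic ring and show only that every compound tested stays at the limit. With no readable step, no change beyond the scatter is expected in this assay, and the most likely outcome is another limit. Compound 4 is therefore expected to give 8000 nM in this assay, within 4000 nM to 30000 nM. The implied step that the limit leaves unreadable from compound 3 to compound 4 is expected to be no more than scatter.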

Compound 4, half-maximal cytotoxic concentration: > 5000 nM
Compound 4: only a limit was reported (the forecaster's own chance of this, stated with the estimate: 85%); the middle value does not contradict the limit.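

In this assay compound 4 gives > 5000 nM, a limit and not a number, so the steps to compound 4 from compound 1, compound 2 and compound 3 cannot be read: the limit of > 5000 nM in this assay, at which 4 of the 4 values shown sit.

The compounds shown leave open the actual half-maximal cytotoxic concentration of each compound, and whether changes on the amine nitrogen or the oxygen shift it.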